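A thiophene in place of a methoxyphenyl on the ester

The compounds below may be only part of what the source reports. "The series", "measured", "known", "first", "only" and "open" are said of these compounds alone.

Compound 1 `C=C1C(=O)O[C@H]2CC3=C[C@H](C/C(C)=C/[C@@H](OC(=O)c4ccc(-c5ccccc5)cc4)[C@H]12)OC3=O` and compound 3 `C=C1C(=O)O[C@H]2CC3=C[C@H](C/C(C)=C/[C@@H](OC(=O)C4(NC(=O)OCc5ccccc5)CC4)[C@H]12)OC3=O` share their core with compound 2 `C=C1C(=O)O[C@H]2CC3=C[C@H](C/C(C)=C/[C@@H](OC(=O)/C=C/c4cccc(OC)c4)[C@H]12)OC3=O` and differ from it only in the ester carried on that core. In a functional assay on NCI-H460 cells (Homo sapiens) for cytotoxicity, read by MTT assay, with a stated time of 48 h (on this read-out higher numbers stand for weaker inhibition and lower numbers for stronger inhibition), compound 1 gives 3500 nM and compound 3 gives 3000 nM. Compound 2 returns only a limit of this assay, > 10000 nM, and the limit of > 10000 nM in this assay, at which 1 of the 3 values shown sits, shows where it stands among the three numbers at hand. Compound 4 `C=C1C(=O)O[C@H]2CC3=C[C@H](C/C(C)=C/[C@@H](OC(=O)/C=C/c4cccs4)[C@H]12)OC3=O` is the unmeasured analogue in which (thiophen-2-yl in place of 3-methoxyphenyl on a double-bonded chain carbon bound to a double-bonded chain carbon). No measured step between any two of these compounds exists, so the expected change from compound 2 to compound 4 in this assay, an at least 1.2-fold lower number from compound 2 to compound 4 (0.09 log units; that floor lies within the scatter), is estimated to be modest and may not clear the scatter. Compound 4 is therefore expected to give 8000 nM in this assay, within 3000 nM to 30000 nM.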

Compound 4, half-maximal inhibitory concentration: 2900 nM
The estimate for compound 4 lay 2.8-fold (0.44 log units) above the measured number; the measured number lies below the stated range.
By their numbers in this assay, from the lowest: compounds 4, 3 and 1 (each within the scatter of the next). At a limit, above all of these: compound 2.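

With the ethenyl chain kept, thiophen-2-yl in place of 3-methoxyphenyl on a double-bonded chain carbon bound to a double-bonded chain carbon gives an at least 3.4-fold lower number from compound 2 to compound 4 (0.53 log units; beyond the scatter) in this assay. For the compounds shown here, this is the first measured step in the set, and it shows that the ring at the end of this chain alone can move the number beyond the scatter. Compound 2 holds only a limit of the assay, so the full size of the step stays unknown: the limit of > 10000 nM in this assay, at which 1 of the 4 values shown sits.

From the compounds shown here alone, whether a furan-2-yl, a pyridin-2-yl or an unsubstituted phenyl on the same chain would follow thiophen-2-yl remains open. So does whether a 3-hydroxyphenyl would follow 3-methoxyphenyl.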